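The compounds below may be only part of what the source reports. "The series", "measured", "known", "first", "only" and "open" are said of these compounds alone.

In a functional assay on QGY-7703 cells (Homo sapiens) for cytotoxicity, read by MTT assay, with a stated time of 24 h (on this read-out lower numbers stand for stronger inhibition and higher numbers for weaker inhibition), compound 3 `CC(=O)Nc1ccc(S(=O)(=O)N2C/C(=C\c3cccc([N+](=O)[O-])c3)C(=O)/C(=C/c3ccccc3F)C2)cc1` gives 7850 nM and lies within the scatter of both relatives: compound 1 `CC(=O)Nc1ccc(S(=O)(=O)N2C/C(=C\c3cccc([N+](=O)[O-])c3)C(=O)/C(=C/c3cccc([N+](=O)[O-])c3)C2)cc1` gives 6760 nM and compound 2 `O=C1/C(=C/c2cccc([N+](=O)[O-])c2)CN(S(=O)(=O)c2ccc(F)cc2)C/C1=C\c1ccccc1F` gives 14900 nM as its value. Still unmeasured, compound 4 `COc1cc(/C=C2\CN(S(=O)(=O)c3ccc(NC(C)=O)cc3)C/C(=C\c3ccccc3F)C2=O)cc(OC)c1` differs from compound 3 by 3,5-dimethoxyphenyl in place of 3-nitrophenyl on a double-bonded chain carbon bound to a double-bonded ring carbon and nothing else. At that same place, 2-fluorophenyl in place of 3-nitrophenyl gave a 1.2-fold higher number from compound 1 to compound 3 (0.06 log units; within the scatter) and acetamido in place of fluoro on an aromatic carbon gave a 1.9-fold lower number from compound 2 to compound 3 (0.28 log units; within the scatter) as the other measured step. For the measured compounds named here, no measured compound carries 3,5-dimethoxyphenyl, so no step beyond the scatter is expected in this assay and neither direction is favoured. The estimated step is a 1.0-fold higher number from compound 3 to compound 4 (0.01 log units; within the scatter) for this exchange. Compound 4 is expected at 8000 nM with an estimated range from 3500 nM to 18000 nM for its value.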

Compound 4, half-maximal inhibitory concentration: 3690 nM
For compound 4 the middle estimate is 2.2-fold (0.34 log units) above the measured one; low and high end bracket the measured number.
By their numbers in this assay, from the lowest: compounds 4, 1, 3 and 2 (each within the scatter of the next, the first and the last beyond it).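

On a double-bonded chain carbon bound to a double-bonded ring carbon, this assay now records a modest step beyond the scatter when 3,5-dimethoxyphenyl replaces 3-nitrophenyl (a 2.1-fold lower number from compound 3 to compound 4 (0.33 log units; beyond the scatter)). For the compounds shown here, the earlier exchange at this place, 2-fluorophenyl for 3-nitrophenyl, stayed within the scatter (a 1.2-fold higher number from compound 1 to compound 3 (0.06 log units; within the scatter)), so this is the first sign that the group here can shift the number. No measurement at hand explains the step.

On these data alone, whether the lower number follows from the methoxy groups or from the loss of the nitro group stays open. Plain phenyl or 3-aminophenyl at this place could help separate the two.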